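Secondary amide variation on a thienyl pyrimidinone scaffold

A few compounds are considered here, and "the series" means these few. Any claim that something is new, unique, unknown or untested is made for them only; others in the source may bear on it.

Compound 1 `CCCNC(=O)c1nc(-c2cccs2)[nH]c(=O)c1O`: > 100000 nM
Compound 2 `O=C(NCCO)c1nc(-c2cccs2)[nH]c(=O)c1O`: > 100000 nM
Compound 3 `O=C(c1nc(-c2cccs2)[nH]c(=O)c1O)N1CCCC1`: "not determined" (no result reported)

The three measured compounds share one core and differ only in the group on the carbonyl carbon. In an assay on isolated protein for inhibition of deoxyribonuclease-1 (Homo sapiens) (on this read-out higher numbers stand for weaker inhibition and lower numbers for stronger inhibition), compound 1 gives > 100000 nM, which is a limit of the assay and not a number. Compound 2 likewise gives > 100000 nM in this assay, again a limit rather than a measured value. Because both values sit at the limit of > 100000 nM in this assay, at which 2 of the 3 values shown sit, the step that the two limits leave unreadable from compound 1 to compound 2 cannot be read in size. Compound 3 stands apart: no result is reported for it in this assay, so it has no place among the numbers.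

Compound 4 `CCC(C)NC(=O)c1nc(-c2cccs2)[nH]c(=O)c1O` is not yet measured. It differs from compound 3 by (sec-butyl)amino in place of pyrrolidin-1-yl on a carbonyl carbon. Among the compounds with values here, no measured step covers this exchange directly; the only step on record, from compound 1 to compound 2, is unreadable because both ends sit at the limit of > 100000 nM in this assay, at which 2 of the 3 values shown sit. The nearest comparison is compound 1, whose secondary amide gives > 100000 nM in this assay, a limit. On that basis compound 4, also a secondary amide, is expected to sit at the same limit, with an estimated value of 150000 nM (range 50000 nM to 500000 nM).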

Compound 4, half-maximal inhibitory concentration: > 100000 nM
Compound 4: a limit, no number (the forecaster's own chance of this, stated with the estimate: 85%); the middle value is on the limit's open side.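

In this assay compound 4 gives > 100000 nM and this is a limit, not a number. No new step can be read, since the steps to compound 4 from compound 1 and from compound 2 join limits only: the limit of > 100000 nM in this assay, at which 3 of the 4 values shown sit. The compounds shown leave open how far compound 1, compound 2 and compound 4 lie past that limit, and where compound 3 stands.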